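A few compounds are considered here, and "the series" means these few. Any claim that something is new, unique, unknown or untested is made for them only; others in the source may bear on it.

Three compounds in this series share a core and are distinguished only by the group on the saturated chain carbon bound to the amine nitrogen in the ring. Compound 1 `CCCn1cnc(CN2CCN(c3cccc4[nH]c(-c5ccc(C(C)(C)C)cc5)nc34)CC2)c1C` gives 12 nM in an assay on isolated protein for displacement of a labelled ligand from Gonadotropin-releasing hormone receptor (Homo sapiens); a lower number here means a stronger inhibitor, a higher number a weaker inhibitor. Compound 2 `CCCCn1cnc(CN2CCN(c3cccc4[nH]c(-c5ccc(C(C)(C)C)cc5)nc34)CC2)c1C`, in which the change methyl in place of hydrogen on a saturated chain carbon, three bonds along the chain from an aromatic nitrogen has been made, gives 46 nM in this assay, so that the step of a 3.8-fold higher number from compound 1 to compound 2 (0.58 log units; beyond the scatter) is modest but clearly outside the scatter. Compound 3 `CCn1cc(CN2CCN(c3cccc4[nH]c(-c5ccc(C(C)(C)C)cc5)nc34)CC2)nc1C` carries a different imidazole, described by 1-ethyl-2-methyl-1H-imidazol-4-yl in place of 5-methyl-1-propyl-1H-imidazol-4-yl on a saturated chain carbon bound to an amine nitrogen in a ring, and gives 10 nM in this assay; the step of a 1.2-fold lower number from compound 1 to compound 3 (0.08 log units; within the scatter) lies within the scatter, whereas the step of a 4.6-fold lower number from compound 2 to compound 3 (0.66 log units; beyond the scatter) does not.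

Compound 4 `CCCn1cc(CN2CCN(c3cccc4[nH]c(-c5ccc(C(C)(C)C)cc5)nc34)CC2)nc1C` has not yet been measured. It differs from compound 3 by methyl in place of hydrogen on a saturated chain carbon, two bonds along the chain from an aromatic nitrogen. This is the same kind of change as that from compound 1 to compound 2, but not the same: there the methyl entered three bonds along the chain from an aromatic nitrogen, here it enters two bonds along the chain from an aromatic nitrogen, and the two cores differ as set out under (1-ethyl-2-methyl-1H-imidazol-4-yl in place of 5-methyl-1-propyl-1H-imidazol-4-yl on a saturated chain carbon bound to an amine nitrogen in a ring). Among the measured compounds shown here, because the only comparable step, a 3.8-fold higher number from compound 1 to compound 2 (0.58 log units; beyond the scatter), weakened binding, compound 4 is expected to give a somewhat higher number than compound 3, with the step of a 2.0-fold higher number from compound 3 to compound 4 (0.30 log units; within the scatter) estimated as smaller, since the chains and cores are not identical. The estimate for compound 4 in this assay is 20 nM, expected to fall between 8 nM and 50 nM.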

Compound 4, half-maximal inhibitory concentration: 18 nM
The estimate for compound 4 lay 1.1-fold (0.05 log units) above the measured number; the measured number falls inside the stated range.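

On the core of compound 3, the added methyl gives a 1.8-fold higher number from compound 3 to compound 4 (0.26 log units; within the scatter) in this assay, and this step and the earlier one on the other core do not differ by more than the scatter allows: the same change on two cores in this assay, a 3.8-fold higher number (0.58 log units; beyond the scatter) from compound 1 to compound 2 and a 1.8-fold higher number (0.26 log units; within the scatter) from compound 3 to compound 4, 2.1-fold (0.33 log units) apart, within the scatter of two such steps The two pairs are therefore compatible with the change carrying over between these cores, but they do not establish that it does or fix the size of its effect, and only the earlier step lies beyond the scatter. With the propyl chain kept, moving to the 2-methyl-1-propyl-1H-imidazol-4-yl group gives a 1.5-fold higher number from compound 1 to compound 4 (0.18 log units; within the scatter), which cannot be told apart from repeat measurement, whereas the change from the 1-butyl-5-methyl-1H-imidazol-4-yl group gives a 2.6-fold lower number from compound 2 to compound 4 (0.41 log units; beyond the scatter), a modest step.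

The compounds shown leave open whether the trend seen with added chain length continues to a pentyl chain, or how a branched isopropyl group would compare with the propyl chain on either core. They also leave open what a chain carrying a hydroxyl or an amine would give in this assay.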